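Compound 4: a methylated amide against its parent

The source may report more compounds than this note shows. Statements on the series, on what has been measured and on what is new or still open speak of the compounds shown alone.

Compound 2 `O=C(Nc1ccccc1)c1cnc(NCc2c(F)ccc3c2CCO3)n2cnnc12` gives the highest reading of the three in a physicochemical assay for lipophilicity, using the shake flask method, in phosphate buffer, measured as octanol-water partition, with a stated time of 30 min, at pH 7.4 (on this read-out lower numbers stand for lower lipophilicity and higher numbers for higher lipophilicity), at 4.1. Going by the values given here, compound 3 `Cc1nn(C)cc1-c1cnc(NCc2c(F)ccc3c2CCO3)c2cn[nH]c(=O)c12` gives 2.8, and compound 1 `CNC(=O)c1cc(-c2cnc(NCc3c(F)ccc4c3CCO4)c3cn[nH]c(=O)c23)n(C)n1` gives 2.1; the single measured step, a number 0.70 log units higher from compound 1 to compound 3 (beyond the scatter), concerns another part of the shared core of those two compounds and offers no direct guide here. Compound 4 `CN(C(=O)c1ccccc1)c1cnc(NCc2c(F)ccc3c2CCO3)n2cnnc12` differs from compound 2 in one place: benzoyl(methyl)amino in place of phenylcarbamoyl on an aromatic carbon. Among the compounds with values here, no measured pair mirrors that exchange, so the expectation can lean only on the general size of the steps seen so far. For compound 4 a rise of a number 0.30 log units higher from compound 2 to compound 4 (within the scatter) is expected, giving an estimate of 4.4, somewhere between 3.9 and 4.9.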

Compound 4, distribution coefficient: 2.4
Compound 4: middle estimate off by 2.00 log units, on the high side; measured number below the stated range.
By their numbers in this assay, from the lowest: compounds 1 and 4 (each within the scatter of the next); then compound 3; then compound 2.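

In this assay this aromatic carbon proves sensitive to how the amide is attached: benzoyl(methyl)amino in place of phenylcarbamoyl gives a number 1.70 log units lower from compound 2 to compound 4 (beyond the scatter). The number falls even though the entering group has 10 heavy atoms against 9, with 0 hydrogen-bond donors against 1. No measurement shown here accounts for the fall. The compounds shown leave open which part of the exchange carries the step. A benzoylamino group without the methyl would separate the two at this position, and acetyl(methyl)amino would test the role of the phenyl ring.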